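Lengthening the phenyl-bearing chain from compound 2 to compound 3

The compounds below may be only part of what the source reports. "The series", "measured", "known", "first", "only" and "open" are said of these compounds alone.

- compound 1 `CCCCC(=O)Nc1nc2ccccc2n1CCC`: 25000 nM
- compound 2 `CCCn1c(NC(=O)CCc2ccccc2)nc2ccccc21`: > 50000 nM

In an ADME assay on H9c2 cells (Rattus norvegicus) for cytotoxicity (a higher number here means that more compound is tolerated, a lower number that less compound is tolerated), compound 2 reads > 50000 nM, which is a limit of the assay and not a number. The relevant context is the limit of > 50000 nM in this assay, at which 1 of the 2 values shown sits. Compound 3 `CCCn1c(NC(=O)CCCc2ccccc2)nc2ccccc21` carries one change from compound 2: benzyl in place of phenyl on a saturated chain carbon, two bonds along the chain from a carbonyl carbon. In words, this is benzyl in place of phenyl on a saturated chain carbon, two bonds along the chain from a carbonyl carbon.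

Among the compounds with values here, the one measured step at this place is an at least 2.0-fold higher number from compound 1 to compound 2 (0.30 log units; that floor lies within the scatter). Its floor gives no firm size, so no step beyond the scatter is expected in this assay, in either direction. For compound 3 the expected value is 50000 nM, with an estimated range of 20000 nM to 120000 nM. The estimate means an expected a number no higher from compound 2 to compound 3 (the limit leaves the size open).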

Compound 3, half-maximal cytotoxic concentration: 16000 nM
Beside the measured number, compound 3's estimate is 3.1-fold (0.49 log units) above it; measured number below the stated range.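

In this assay, within the data shown here, benzyl in place of phenyl on a saturated chain carbon, two bonds along the chain from a carbonyl carbon, gives an at least 3.1-fold lower number from compound 2 to compound 3 (0.49 log units; beyond the scatter), the first step printed as beyond the scatter. Phenyl in place of methyl on a saturated chain carbon, three bonds along the chain from a carbonyl carbon, gives a 1.6-fold lower number from compound 1 to compound 3 (0.19 log units; within the scatter), so compound 1 and compound 3 cannot be told apart in this read-out. Compound 2 gives > 50000 nM, a limit of the assay and not a number, so the size of its step to compound 3 remains a floor because of this limit: the limit of > 50000 nM in this assay, at which 1 of the 3 values shown sits.

On these data alone, whether a longer chain carrying the phenyl ring lowers the tolerated concentration further remains open. Also open, as far as these compounds go, is how an amine or a carboxylic acid in place of the benzyl would read at this position.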